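From 4-fluorophenoxy to 2-hydroxyphenoxy on the shared core

This account rests on a few compounds, and the source may have more. Where it says the series, first, only, none or still open, it means among the compounds named here.

Of the compounds shown here, three sharing one core have been measured in a functional assay for inhibition, with Homo sapiens as the target; a higher number here means weaker binding, a lower number tighter binding. Compound 1 (`O=C(O)CC/C=C\CC1COC(c2ccccc2Cl)OC1c1cccnc1`) gives 759 nM and compound 2 (`N#Cc1ccc(C2OCC(C/C=C\CCC(=O)O)C(c3cccnc3)O2)cc1`) gives 1290 nM. Compound 3 (`CC(C)(Oc1ccc(F)cc1)C1OCC(C/C=C\CCC(=O)O)C(c2cccnc2)O1`) gives 120 nM, the lowest number of the three and beyond the scatter from both of the others.

Compound 4 (`CC(C)(Oc1ccccc1O)C1OCC(C/C=C\CCC(=O)O)C(c2cccnc2)O1`) has not yet been measured. It differs from compound 3 by a single change, 2-hydroxyphenyl in place of 4-fluorophenyl on an oxygen on a saturated carbon.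

Among the measured compounds shown here, only one measured step exchanges one substituted phenyl group for another, and it gives a 1.7-fold higher number from compound 1 to compound 2 (0.23 log units; within the scatter). That exchange sits on a saturated ring carbon, not on the oxygen that carries the present change, so it is only an indirect guide. For the measured compounds named here, no measured compound carries a 2-hydroxyphenyl group, and no measured step alters the group on that oxygen. With this little evidence, no step beyond the scatter is expected in this assay, in either direction. The estimated change is a 1.3-fold lower number from compound 3 to compound 4 (0.12 log units; within the scatter), and the uncertainty around it is wide. Compound 4 is expected near 90 nM, with an estimated range of 25 nM to 320 nM.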

Compound 4, dissociation constant: 95.5 nM
Beside the measured number, compound 4's estimate is 1.1-fold (0.03 log units) below it, within the range that was stated.
By their numbers in this assay, from the lowest: compounds 4 and 3 (each within the scatter of the next); then compounds 1 and 2 (each within the scatter of the next).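

In this assay, among the compounds shown here, this is the first step that touches the group on the oxygen on a saturated carbon, and it reads a 1.3-fold lower number from compound 3 to compound 4 (0.10 log units; within the scatter) for the exchange of 4-fluorophenyl for 2-hydroxyphenyl. For the compounds shown here, the earlier compounds offered only an exchange of one substituted phenyl group for another on a saturated ring carbon, so this step is the first direct reading at this oxygen, and it shows that the number holds within the scatter here. It holds even though the fluorine leaves and the entering group brings a hydrogen-bond donor and a hydrogen-bond acceptor that the leaving group does not have, and no measurement at hand explains this result.

The compounds shown leave open whether the hydroxyl matters at all at this oxygen, since they include neither a plain phenyl nor a 2-methoxyphenyl group there. As far as these compounds go, it also remains open how far the exchange can go, for instance to a phenyl group carrying an amine or a carboxylic acid, or to a pyridyl group in place of the phenyl.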